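Shifting the aryl substituent on a thiazolidinone core

The source may hold more compounds than are shown below. What is called first, only, known or untested is meant among the compounds shown, and "the series" means these compounds.

Compound 2 `CN(C)c1ccc(/C=C2/SC(=Nc3ccc(O)cc3)NC2=O)cc1` is the second highest of three numbers in a functional assay on NCI-H460 cells (Homo sapiens) for antiproliferative activity (a higher number here means a weaker inhibitor, a lower number a stronger inhibitor), where compound 2 gives 1080 nM. Its nearest neighbour is compound 3 `CN(C)c1ccc(/C=C2/S/C(=N/c3ccc(Cl)cc3)NC2=O)cc1`, which in this assay gives 2930 nM; the furthest is compound 1 `CN(C)c1ccc(/C=C2/SC(=Nc3ccccc3)NC2=O)cc1`, which gives 210 nM. Among the compounds with values here, the one step that bears on the new compound is a 5.1-fold higher number from compound 1 to compound 2 (0.71 log units; beyond the scatter), showing that adding a group to the aryl ring raises the number. Compound 4 `CN(C)c1ccc(/C=C2/SC(=Nc3ccccc3Cl)NC2=O)cc1` carries the change (2-chlorophenyl in place of 4-hydroxyphenyl on a double-bonded nitrogen). Within the data shown here, no measured step covers a chlorine at this place, and compound 3 only shows that another chlorophenyl sits high. A modest rise or no change beyond the scatter is therefore expected, a 1.4-fold higher number from compound 2 to compound 4 (0.14 log units; within the scatter). Compound 4 is estimated at 1500 nM, ranging from 400 nM to 6000 nM.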

Compound 4, half-maximal inhibitory concentration: 880 nM
Estimate against measurement, compound 4: 1.7-fold (0.23 log units) above; the measured number falls inside the stated range.
By their numbers in this assay, from the lowest: compound 1; then compounds 4 and 2 (each within the scatter of the next); then compound 3.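

In this assay, 2-chlorophenyl in place of 4-hydroxyphenyl on the double-bonded nitrogen gives a 1.2-fold lower number from compound 2 to compound 4 (0.09 log units; within the scatter), so these two groups cannot be told apart here, although the hydrogen-bond donor and acceptor of the leaving group are gone. Chloro in place of hydrogen gives a 4.2-fold higher number from compound 1 to compound 4 (0.62 log units; beyond the scatter), so a second substituent on this aryl ring, after hydroxy, goes with a higher number than the unsubstituted phenyl. Nothing available explains either step. As far as these compounds go, whether an amine or a carboxylic acid on this ring would also raise the number stays open.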